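Removing a pyridinyl Group: Expected Toxicity of Compound 4

The source may report more compounds than this note shows. Statements on the series, on what has been measured and on what is new or still open speak of the compounds shown alone.

This piece concerns toxicity toward a human monocytic cell line, recorded in a toxicity assay on THP-1 cells (Homo sapiens) for inhibition; on this read-out higher numbers stand for lower toxicity in this test and lower numbers for higher toxicity in this test. Compound 1 `CCCC(=O)Nc1ncc(-c2ccc(OC)cc2)n1C` carries a propyl group on the carbonyl carbon. In this assay compound 1 gives > 100000 nM as a limit of the assay rather than a number. Compound 2 `COc1ccc(-c2cnc(NC(=O)c3cnc[nH]3)n2C)cc1` has 1H-imidazol-5-yl in place of propyl on that carbonyl carbon. In this assay compound 2 gives > 100000 nM as a limit as well. The step that the two limits leave unreadable from compound 1 to compound 2 therefore has no readable size. Compound 3 `COc1ccc(-c2cnc(NC(=O)c3cc(-c4ccccn4)n[nH]3)n2C)cc1` carries a pyridin-2-yl group on the five-membered ring joined to the carbonyl. In this assay compound 3 gives >= 50000 nM as a limit too. Compound 3 thus stands where every measured compound stands, at a limit, as summarised by the limit of > 100000 nM in this assay, at which 2 of the 3 values shown sit, and (the limit of >= 50000 nM in this assay, at which 1 of the 3 values shown sits).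

Compound 4 `COc1ccc(-c2cnc(NC(=O)c3ccn[nH]3)n2C)cc1` differs from compound 3 in one place: hydrogen in place of pyridin-2-yl on an aromatic carbon. Within the data shown here, no measured step covers the loss of a pyridin-2-yl group, and the single measured step is unreadable, so the values shown point to no step beyond the scatter. Compound 4 is therefore expected to give 100000 nM, within 50000 nM to 200000 nM, most likely again reported as a limit. The expected step that the limit leaves unreadable from compound 3 to compound 4 is essentially none.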

Compound 4, half-maximal cytotoxic concentration: > 100000 nM
Compound 4 was reported as a limit; the forecaster's own chance of this, stated with the estimate: 85%; the middle value lies on the limit itself.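

In this assay compound 4 gives > 100000 nM, a limit of the assay and not a number. Among these compounds, compound 1, compound 2 and compound 3 also stand at limits, so no step to compound 4 from any of them can be read. The compounds shown leave open whether any of these changes alters toxicity at all.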